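The compounds below may be only part of what the source reports. "The series", "measured", "known", "first", "only" and "open" are said of these compounds alone.

The study centres on a shared core carried by compound 1 `O=C([C@@H]1C[C@H](N2CCN(c3ccccn3)CC2)CN1)N1CCSC1` and compound 2 `O=C([C@@H]1C[C@H](N2CCC(c3ccccc3)CC2)CN1)N1CCSC1`. In an assay on a cell-free system (plasma) for inhibition of Dipeptidyl peptidase 4 (Rattus norvegicus), read by fluorescence (on this read-out higher numbers stand for weaker inhibition and lower numbers for stronger inhibition), compound 1 gives 3.5 nM, and in this assay compound 2 gives 9.6 nM. Of the two numbers recorded so far, compound 1 stands at the lowest, and its nearest neighbour, compound 2, sits at a higher number by a gap that lies beyond the usual scatter. For the measured compounds named here, no single-point step between measured compounds is available, so the pair shows only what its two values show.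

The next compound, compound 3 `O=C([C@@H]1C[C@H](N2CCN(c3ccc(Cl)c(Cl)c3)CC2)CN1)N1CCSC1`, departs from compound 1 by one change: 3,4-dichlorophenyl in place of pyridin-2-yl on an amine nitrogen in a ring. Going by the values given here, since no measured step of this kind is at hand, the expectation rests on compound 1 at 3.5 nM and on compound 2 at 9.6 nM as the range of what this core has given. The step from compound 1 to compound 3 is expected to be small, a modest rise toward a higher number or none beyond the scatter, as a 1.7-fold higher number from compound 1 to compound 3 (0.23 log units; within the scatter) expresses. Compound 3 is therefore estimated to give 6 nM in this assay, with a range from 2 nM to 20 nM.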

Compound 3, half-maximal inhibitory concentration: 4.2 nM
For compound 3 the middle estimate is 1.4-fold (0.15 log units) above the measured one, and the stated range covers the measured number.
By their numbers in this assay, from the lowest: compounds 1 and 3 (each within the scatter of the next); then compound 2.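

For the compounds shown here, the step gives the first single-change reading at this position: in this assay, replacing pyridin-2-yl with 3,4-dichlorophenyl on the amine nitrogen in the ring gives a 1.2-fold higher number from compound 1 to compound 3 (0.08 log units; within the scatter), which lies within the scatter. For this pair, then, a carbon-only aromatic ring bearing two chlorines and no hydrogen-bond acceptor reads the same as a pyridine ring with a ring nitrogen and one hydrogen-bond acceptor, so neither that ring nitrogen nor that acceptor is needed here to hold the number at this level. No measurement at hand accounts for this lack of change.

The single step replaces the ring nitrogen and adds both chlorines at once, so the compounds shown cannot separate what each part contributes, and effects of opposite sign that cancel cannot be ruled out. As far as these compounds go, it also remains open whether this tolerance extends beyond aromatic rings, or whether it would hold for an unsubstituted phenyl, a 4-chlorophenyl, or a simple chain such as ethyl on the same nitrogen.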